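This account rests on a few compounds, and the source may have more. Where it says the series, first, only, none or still open, it means among the compounds named here.

Measured so far:
- compound 1, `COc1ccc2ncc(S(=O)(=O)c3cc(F)cc(F)c3)c(N3CCC(C)CC3)c2c1`: 30%
- compound 2, `COc1ccc(S(=O)(=O)c2cnc3ccc(Cl)cc3c2N2CCC(C)CC2)cc1OC`: 61%

Both numbers come from an assay on isolated protein for displacement of a labelled ligand from metabotropic glutamate receptor 5 (Homo sapiens), with a stated time of 60 min, tested at 1 uM; on this read-out lower numbers stand for less inhibition and higher numbers for more inhibition at the one concentration tested (going by the name of the read-out). Compound 2 stands highest of the two: in this assay compound 2 gives 61%, while compound 1 gives 30%, a number lower by a margin beyond the usual scatter. For the measured compounds named here, no step between the two measured compounds is worked out, since they differ in more than one place; the pair only shows that the two values lie well apart.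

Compound 3, `COc1ccc2ncc(S(=O)(=O)c3ccc(OC)c(OC)c3)c(N3CCC(C)CC3)c2c1`, has not yet been measured. It differs from compound 2 in one place: methoxy in place of chloro on an aromatic carbon. Nothing measured bears directly on this exchange, so the size of the step is open. A modest fall from compound 2 to compound 3 is expected, of a size that may not clear the scatter, as a number 16 percentage points lower from compound 2 to compound 3 (beyond the scatter). In this assay compound 3 is estimated at 45%, with a plausible range from 15% to 75%.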

Compound 3, a percentage reported as inhibition, at one concentration (the size of the read-out at that concentration, not a potency): -3%
Beside the measured number, compound 3's estimate is 48 percentage points above it, outside the stated range (below it).
By their numbers in this assay, from the lowest: compound 3; then compound 1; then compound 2.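

In this assay the carbon of the core bearing chloro in compound 2 proves far from indifferent to its substituent: with 3,4-dimethoxyphenyl held on the sulfonyl sulfur, methoxy in place of chloro gives a number 64 percentage points lower from compound 2 to compound 3 (beyond the scatter) and this single exchange isolates that position, which the earlier pair could not do. The sulfonyl substituent also matters with methoxy held on the core, since 3,4-dimethoxyphenyl in place of 3,5-difluorophenyl gives a number 33 percentage points lower from compound 1 to compound 3 (beyond the scatter) in the same assay. Compound 3 at -3% is therefore the lowest of the three, and nothing at hand accounts for either step.

Open, from the compounds shown here alone, is whether the fall at the core position is specific to methoxy or would also follow from another group there, such as fluoro, methyl or a nitrile. Also open, going by these compounds, is whether the two changes act independently of each other, a question that chloro on the core paired with 3,5-difluorophenyl on the sulfonyl sulfur would address.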